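A few compounds are considered here, and "the series" means these few. Any claim that something is new, unique, unknown or untested is made for them only; others in the source may bear on it.

Compounds measured in an ADME assay on the whole organism with Oryza sativa as the target, tested at 1 uM; on this read-out lower numbers stand for a stronger effect and higher numbers for a weaker effect at the one concentration tested:
- compound 1 `Cc1cccc(NC(=O)N[C@@H](C)c2ccccc2)c1`: 100%
- compound 2 `C[C@H](NC(=O)Nc1cccc(C(F)(F)F)c1)c1ccccc1`: 93%
- compound 3 `C[C@H](NC(=O)Nc1cccc(Cl)c1)c1ccccc1`: 99%

Compound 3 stands in the middle of the three numbers, all of which lie within the scatter of one another: a number 1 percentage points lower from compound 1 to compound 3 (within the scatter), and a number 6 percentage points higher from compound 2 to compound 3 (within the scatter). Compound 4 `C[C@H](NC(=O)Nc1cccc(I)c1)c1ccccc1` has not yet been measured in this assay. It differs from compound 3 in one place: iodo in place of chloro on an aromatic carbon.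

Among the measured compounds shown here, no measured step exchanges one halogen for another, so the bearing steps are only those that bring the chloro in: the change from compound 1 to compound 3 and the change from compound 2 to compound 3, both of which stayed within the scatter. The three replacements at this position have thus left this assay essentially unchanged, and the same is expected of iodo in place of chloro. The expected step is therefore none beyond the scatter: a number 2 percentage points lower from compound 3 to compound 4 (within the scatter). Compound 4 is estimated at 97%, with a range from 87% to 104%.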

Compound 4, a percentage reported as activity, at one concentration (the size of the read-out at that concentration, not a potency): 95%
The estimate for compound 4 lay 2 percentage points above the measured number; the range from low to high includes it.
By their numbers in this assay, from the lowest: compounds 2, 4, 3 and 1 (each within the scatter of the next).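

In this assay, the exchange of one halogen for another on this aromatic carbon stays within the scatter: a number 4 percentage points lower from compound 3 to compound 4 (within the scatter). Iodo also stays within the scatter of the other two groups, with a number 2 percentage points higher from compound 2 to compound 4 (within the scatter) and a number 5 percentage points lower from compound 1 to compound 4 (within the scatter), so methyl, trifluoromethyl, chloro and iodo at this place cannot be told apart by this assay. Nothing available here offers an explanation for this flat result.

As far as these compounds go, it remains open whether a group of another kind on this carbon, such as an amine, a carboxylic acid or a longer chain, would carry the number beyond the scatter. Also open, from the compounds shown here alone, is whether these four compounds would still sit together at any concentration other than the single one tested, or after a change elsewhere on the shared core.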